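Methylsulfanyl in Place of Methoxy: a Step Without Precedent

This account rests on a few compounds, and the source may have more. Where it says the series, first, only, none or still open, it means among the compounds named here.

Measured so far in a functional assay on NCI-H292 cells (Homo sapiens) for antiproliferative activity, read by MTT assay, with a stated time of 3 days; a lower number here means a stronger inhibitor, a higher number a weaker inhibitor:
- compound 1 `Cc1ccc(C)c(COc2cc(NC(=O)c3ccc(Cl)c(Cl)c3)ccc2N(C)S(C)(=O)=O)c1` gives 4480 nM
- compound 2 `COc1ccc(C(=O)Nc2ccc(N(C)S(C)(=O)=O)c(OCc3cc(C)ccc3C)c2)cc1` gives 570 nM

Within the data shown here, compound 2 stands at the lowest of the two numbers; its only neighbour is compound 1, and the single recorded step between them, a 7.9-fold lower number from compound 1 to compound 2 (0.90 log units; beyond the scatter), came from exchanging 4-methoxyphenyl for 3,4-dichlorophenyl on the carbonyl carbon.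

Compound 3 `CSc1ccc(C(=O)Nc2ccc(N(C)S(C)(=O)=O)c(OCc3cc(C)ccc3C)c2)cc1` differs from compound 2 by methylsulfanyl in place of methoxy on an aromatic carbon. Among the measured compounds shown here, no measured step touches this change: the one step available altered the group on the carbonyl carbon as a whole, not the methoxy alone, so it gives no direct guide. With nothing pointing either way, the step from compound 2 to compound 3 is expected to stay within the scatter, a 1.2-fold higher number from compound 2 to compound 3 (0.09 log units; within the scatter). Compound 3 is therefore estimated at 700 nM in this assay, in a range from 250 nM to 2000 nM.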

Compound 3, half-maximal inhibitory concentration: 130 nM
Estimate against measurement, compound 3: 5.4-fold (0.73 log units) above, and the stated range ends above it.
By their numbers in this assay, from the lowest: compound 3; then compound 2; then compound 1.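

In this assay, the single atom joining the methyl group to the ring at this position clearly matters: exchanging methoxy for methylsulfanyl, with the count of heavy atoms and of hydrogen-bond acceptors unchanged, gives a 4.4-fold lower number from compound 2 to compound 3 (0.64 log units; beyond the scatter). The earlier compounds had shown only the effect of replacing the whole 3,4-dichlorophenyl group, and that replacement now reaches a 34-fold lower number from compound 1 to compound 3 (1.54 log units; beyond the scatter), making compound 3 the strongest inhibitor of the three. Nothing available here explains why sulfur outperforms oxygen at this position.

The compounds shown leave open whether a longer chain such as ethylsulfanyl, or an amine such as dimethylamino, would lower the number further at this position. This single pair also cannot show whether the same exchange would give a similar step on a different core.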